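A few compounds are considered here, and "the series" means these few. Any claim that something is new, unique, unknown or untested is made for them only; others in the source may bear on it.

Working notes on the series. Compound 1 `O=C(O)Cc1sc(C(c2ccccc2)c2ccccc2)nc1-c1ccccc1` gives 80% in an in vitro functional assay on HEK285-7 cells for antagonist activity at prostaglandin D2 receptor 2 (Homo sapiens), read by BRET and beta-arrestin recruitment; a higher number here means a larger maximal response, a lower number a smaller maximal response. Compound 2 `Cc1nc(-c2ccc(Cl)cc2)c(CC(=O)O)s1` gives 50% in this assay. Compound 3 `O=C(O)Cc1sc(C(c2ccc(F)cc2)c2ccc(F)cc2)nc1-c1ccccc1` gives 80% in this assay. Compound 3 stands level with compound 1 at the digits shown; together they are the highest of the three numbers, and the gap between them lies within the scatter. Compound 2 is the furthest from compound 3, lower by a margin beyond the scatter. Compound 4 `Cc1cc(-c2nc(C(c3ccc(F)cc3)c3ccc(F)cc3)sc2CC(=O)O)cnc1N` has not yet been measured in this assay. It differs from compound 3 in one place: 6-amino-5-methylpyridin-3-yl in place of phenyl on an aromatic carbon. Among the compounds with values here, no pair of measured compounds differing in a single place is available, so no measured step tells the size of such a change. Compound 3 and compound 1 both sit at the upper end, and compound 4 keeps the rest of the structure of compound 3. For compound 4 the value expected in this assay is 75%, with a range from 55% to 90%. The expected step of a number 5 percentage points lower from compound 3 to compound 4 (within the scatter) is estimated to stay within the scatter, if anything slightly downward.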

Compound 4, largest response reached (reported as efficacy), in percent of the reference or control that the assay uses: 80%
For compound 4 the middle estimate is 5 percentage points below the measured one, and the stated range covers the measured number.
By their numbers in this assay, from the lowest: compound 2; then compounds 1, 3 and 4 (each within the scatter of the next).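

At the aromatic carbon next to the ring nitrogen, 6-amino-5-methylpyridin-3-yl in place of phenyl gives no change at the digits printed from compound 3 to compound 4 (within the scatter) in this assay. Within the data shown here, this is the first single-place step: the entering group brings a ring hetero atom, a hydrogen-bond donor and hydrogen-bond acceptors that phenyl lacks, yet the maximal response stays within the scatter. Nothing available explains this outcome.

The amino and methyl groups enter together, so the compounds shown leave open what each does alone on the entering ring. Also open, from the compounds shown here alone, is whether this position would tolerate a group of a different kind, such as a carboxylic acid or a longer alkyl chain, without a step beyond the scatter.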